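The compounds below may be only part of what the source reports. "The series", "measured", "known", "first", "only" and "open" are said of these compounds alone.

In a functional assay on L5178Y cells (Mus musculus) for inhibition, read by MTT assay, with a stated time of 24 h (on this read-out lower numbers stand for stronger inhibition and higher numbers for weaker inhibition), compound 1 (`N/N=C1\C[C@@H](c2ccc(O)cc2)Oc2cc(O)cc(O)c21`) gives >= 11300 nM as a limit. Compound 2 (`CN(C)C(=S)N/N=C1\C[C@@H](c2ccc(O)cc2)Oc2cc(O)cc(O)c21`) gives >= 11300 nM as a limit. Compound 3 (`COc1cc(O)c2c(c1)O[C@H](c1ccc(O)cc1)C/C2=N\N`) gives >= 11300 nM as a limit, and that limit is all that is known of where it stands. Among the compounds with values here, the series so far rests on the limit of >= 11300 nM in this assay, at which 3 of the 3 values shown sit, without a single measured number.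

Compound 4 (`COc1cc(O)c2c(c1)O[C@H](c1ccc(O)cc1)C/C2=N\NC(=O)OCc1ccccc1`) carries benzyloxycarbonyl in place of hydrogen on an amine nitrogen relative to compound 3, that is, benzyloxycarbonyl in place of hydrogen on an amine nitrogen. Within the data shown here, two measured steps bear on this change. The closer one is a step that the two limits leave unreadable from compound 1 to compound 2 as a change on an amine nitrogen too. The other is a step that the two limits leave unreadable from compound 1 to compound 3 and gives the methyl on oxygen that compound 3 and compound 4 share. Neither offers a size or a direction to carry over. The estimated step is a step that the limit leaves unreadable from compound 3 to compound 4 and remains a weak expectation with no firm direction. For compound 4 the expected value is 12000 nM within an estimated range of 4000 nM to 40000 nM in this assay and another limit is quite possible.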

Compound 4, half-maximal inhibitory concentration: >= 11300 nM
Compound 4: a limit, no number; the forecaster's own chance of this, stated with the estimate: 55%; the middle value lies beyond the limit too.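

No step can be read from compound 3 to compound 4, since each stands only as a limit and not as a number: the limit of >= 11300 nM in this assay, at which 4 of the 4 values shown sit. The compounds shown leave open whether any change on the shared core yields a measured inhibition value, and what size or direction the benzyloxycarbonyl change has.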